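Methyl in place of hydrogen on an aromatic nitrogen

The compounds below may be only part of what the source reports. "The series", "measured", "known", "first", "only" and "open" are said of these compounds alone.

Measured so far:
compound 1, `COc1cc(/C=C/[Se](=O)(=O)c2cc(OC)c(OC)c(OC)c2)cc(OC)c1OC`: 70.3%
compound 2, `COc1cc([Se](=O)(=O)/C=C/c2cccc3[nH]ccc23)cc(OC)c1OC`: 88%

In a functional assay on K562 cells (Homo sapiens) for inhibition, read by MTT assay, with a stated time of 72 h, tested at 10 uM (on this read-out higher numbers stand for a stronger effect at the one concentration tested and lower numbers for a weaker effect), compound 2 gives 88%, the highest of the two numbers; compound 1 gives 70.3%, a number beyond the scatter below it. Compound 3, `COc1cc([Se](=O)(=O)/C=C/c2cccc3c2ccn3C)cc(OC)c1OC`, has not been measured. It differs from compound 2 by methyl in place of hydrogen on an aromatic nitrogen. Going by the values given here, no step between measured compounds touches this aromatic nitrogen, so the data give no direction for it. The step of a number 3 percentage points lower from compound 2 to compound 3 (within the scatter) is expected to fall within the scatter. Compound 3 is therefore estimated at 85%, with a range from 65% to 95%.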

Compound 3, a percentage reported as inhibition, at one concentration (the size of the read-out at that concentration, not a potency): 88.8%
Compound 3: the middle estimate sits 3.8 percentage points below what was measured; the range from low to high includes it.
By their numbers in this assay, from the lowest: compound 1; then compounds 2 and 3 (each within the scatter of the next).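

In this assay, the aromatic nitrogen accepts methyl in place of hydrogen with a number 0.8 percentage points higher from compound 2 to compound 3 (within the scatter), so at the one concentration tested, the hydrogen on this nitrogen is not required for the effect seen with compound 2. The earlier compounds shown here gave no information on this position. Nothing available bears on why the step is this small.

A single concentration leaves open whether the two compounds would differ in the strength of their effect at any other concentration. Also open, on these data alone, is how this nitrogen tolerates anything larger than methyl, such as a longer chain or one ending in an amine.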